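A few compounds are considered here, and "the series" means these few. Any claim that something is new, unique, unknown or untested is made for them only; others in the source may bear on it.

Working notes on the series, read in a functional assay on KB cells (Homo sapiens) for cytotoxicity; a lower number here means a stronger inhibitor, a higher number a weaker inhibitor. Compound 1 (`Cc1ccc(S(=O)(=O)N/C(=N\O)Nc2ccc(Cl)cc2)cc1`) gives 46 ug/mL, compound 2 (`Cc1c(S(=O)(=O)N/C(=N\O)Nc2ccc(Cl)cc2)sc2ccc(Cl)cc12`) gives 29 ug/mL and compound 3 (`Cc1c(S(=O)(=O)/N=C(\S)Nc2ccc(Cl)cc2)sc2ccc(Cl)cc12`) gives 61 ug/mL. Compound 3 cannot be separated within the scatter from compound 1 at 46 ug/mL, while its number exceeds that of compound 2 at 29 ug/mL by a margin beyond the scatter.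

The next compound is compound 4 (`Cc1c(S(=O)(=O)/N=C(\S)Nc2ccc(Cl)c(Cl)c2)sc2ccc(Cl)cc12`), still to be measured in this assay. It differs from compound 3 by chloro in place of hydrogen on an aromatic carbon, ortho to a chloro group and meta to a large group, so 4-chlorophenyl becomes 3,4-dichlorophenyl: chloro in place of hydrogen on an aromatic carbon.

For the measured compounds named here, no measured pair isolates this change, so the expectation rests only on the narrow spread of the three values, from compound 2 at 29 ug/mL to compound 3 at 61 ug/mL. A small shift toward a lower number is expected in this assay, probably not beyond the scatter. The expected step is a 1.3-fold lower number from compound 3 to compound 4 (0.10 log units; within the scatter). For compound 4 the estimated value is 48 ug/mL, with an expected range of 22 ug/mL to 100 ug/mL.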

Compound 4, half-maximal inhibitory concentration: 25 ug/mL
The estimate for compound 4 lay 1.9-fold (0.28 log units) above the measured number, and the stated range covers the measured number.
By their numbers in this assay, from the lowest: compounds 4, 2, 1 and 3 (each within the scatter of the next, the first and the last beyond it).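

In this assay the change from 4-chlorophenyl to 3,4-dichlorophenyl gives a 2.4-fold lower number from compound 3 to compound 4 (0.39 log units; beyond the scatter) and lies beyond the scatter. For the compounds shown here, this is the first change confined to one place, and it shows that the number responds to chloro in place of hydrogen on this aromatic carbon, ortho to a chloro group and meta to a large group. The step is modest and comes from a single pair, so it holds for the core of compound 3 only, and no measurement at hand accounts for it.

Whether the lower number is specific to chloro remains open, as the compounds shown include no fluoro, methyl, methoxy or trifluoromethyl group on this carbon, and none with a second chloro group elsewhere on the ring. From the compounds shown here alone, it also remains open whether the same change would give a step of similar size on the core of compound 1 or compound 2, as neither core appears here with a 3,4-dichlorophenyl group.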